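The source may report more compounds than this note shows. Statements on the series, on what has been measured and on what is new or still open speak of the compounds shown alone.

Compounds measured so far in an ADME assay on BJ cells (Homo sapiens) for cytotoxicity, read by CellTiter-Glo and resazurin assay, with a stated time of 72 h; on this read-out lower numbers stand for an effect already at smaller amounts and higher numbers for an effect only at larger amounts of compound:

Compound 1 `CC(C)N(Cc1cccc(OCCCCCC(=O)O)c1)C(=O)c1ccc(-c2ccncc2)cc1` gives > 26000 nM, a limit of the assay.
Compound 2 `CC(C)N(Cc1cccc(OCCCCCC(=O)O)c1)C(=O)c1ccc(-c2ccoc2)cc1` gives > 26000 nM, a limit of the assay.
Compound 3 `CCOc1cccc(-c2ccc(C(=O)N(Cc3cccc(OCCCCCC(=O)O)c3)C(C)C)cc2)c1` gives > 20800 nM, a limit of the assay.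

Compound 2 stands at a limit in this assay, and so do the two other values shown; no number is known for any of them. The steps a step that the two limits leave unreadable from compound 1 to compound 2 and a step that the two limits leave unreadable from compound 2 to compound 3 are therefore unreadable, as is a step that the two limits leave unreadable from compound 1 to compound 3. The evidence rests on two limits, the limit of > 26000 nM in this assay, at which 2 of the 3 values shown sit, and (the limit of > 20800 nM in this assay, at which 1 of the 3 values shown sits).

Compound 4 `COc1ccc(F)c(-c2ccc(C(=O)N(Cc3cccc(OCCCCCC(=O)O)c3)C(C)C)cc2)c1` differs from compound 2 by 2-fluoro-5-methoxyphenyl in place of furan-3-yl on an aromatic carbon. The unreadable steps that bear on it, a step that the two limits leave unreadable from compound 1 to compound 2 and a step that the two limits leave unreadable from compound 2 to compound 3, both link compounds whose values sit at limits, so they give no size and no direction; the expectation for compound 4 in this assay is a value again at a limit, with no step beyond the scatter. Compound 4 is estimated at 26000 nM, within 13000 nM to 60000 nM, which means an expected step of a number no higher from compound 2 to compound 4 (the limit leaves the size open).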

Compound 4, half-maximal effective concentration: > 26000 nM
Compound 4 gave a limit, no number; the forecaster's own chance of this, stated with the estimate: 85%; the middle value lies on the limit itself.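

In this assay, among these compounds, compound 4 gives > 26000 nM, a limit of the assay, and no step linking compound 4 to compound 1, compound 2 or compound 3 can be read. The compounds shown leave open whether swapping the group on that aromatic carbon changes the read-out at all.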